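Two Amine Swaps on Quinone Cores, Both Ending in Limits

The source may hold more compounds than are shown below. What is called first, only, known or untested is meant among the compounds shown, and "the series" means these compounds.

Compound 1 `O=C1C=C(NC2CCCCC2)C(=O)c2c1nc1n2[C@H]2OC[C@@H](O)[C@H]2OC1` carries a cyclohexylamino group on a double-bonded ring carbon of its core. In a functional assay on MGC-803 cells (Homo sapiens) for inhibition, read by sulforhodamine B assay (a lower number here means a stronger inhibitor, a higher number a weaker inhibitor), compound 1 gives only a limit of the assay, > 8000 nM, and no number. Compound 2 `CCCN(CCC)C1=CC(=O)c2nc3n(c2C1=O)[C@H]1OC[C@@H](O)[C@H]1OC3` differs from compound 1 in one place: dipropylamino in place of cyclohexylamino on a double-bonded ring carbon. In this assay compound 2 gives only a limit, > 16000 nM. The step that the two limits leave unreadable from compound 1 to compound 2 cannot be read because the limit of > 16000 nM in this assay, at which 1 of the 3 values shown sits, and the limit of > 8000 nM in this assay, at which 2 of the 3 values shown sit, are both limits of the assay and not numbers.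

Compound 3 `O=C1C(NC2CCCCC2)=CC(=O)c2c1nc1n2[C@H]2OC[C@@H](O)[C@H]2OC1` has the same atoms as compound 1, joined differently; the difference between the two cores is not broken down here. In this assay compound 3 gives only a limit, > 8000 nM.

Compound 4 `CCCN(CCC)C1=CC(=O)c2c(nc3n2[C@H]2OC[C@@H](O)[C@H]2OC3)C1=O` is not yet measured. It differs from compound 3 by the same change that separates compound 2 from compound 1: dipropylamino in place of cyclohexylamino on a double-bonded ring carbon. The place is the same word for word, so this is the same change, and it occurs twice among the compounds shown. Because the limit of > 8000 nM in this assay, at which 2 of the 3 values shown sit, holds two of the three values and the limit of > 16000 nM in this assay, at which 1 of the 3 values shown sits, the third, the first occurrence gives no readable size, and the expectation for compound 4 rests only on the fact that every measured compound here sits at a limit. The step that the limit leaves unreadable from compound 3 to compound 4 is therefore expected to be small or unreadable. Compound 4 is estimated at 16000 nM, most likely reported as another limit, with a range from 6000 nM to 60000 nM.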

Compound 4, half-maximal inhibitory concentration: > 16000 nM
Compound 4: only a limit was reported (the forecaster's own chance of this, stated with the estimate: 85%); the middle value sits exactly at the limit.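

Compound 3 and compound 4 both give only limits of the assay in this assay, not numbers, and the step between them cannot be read. The compounds shown leave open how strongly any of the four inhibits in this assay, and whether dipropylamino in place of cyclohexylamino changes that inhibition at all on either core.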